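The compounds below may be only part of what the source reports. "The series", "measured", "known", "first", "only" and "open" are said of these compounds alone.

Measured compounds:
Compound 1 `O=C(Nc1ccc(Cl)cc1)c1c(NC(=O)C(F)(F)F)sc2c1CCCCC2` — in an ADME assay on THP-1 cells (Homo sapiens) for cytotoxicity (on this read-out lower numbers stand for higher toxicity in this test and higher numbers for lower toxicity in this test), compound 1 gives > 50000 nM, which is a limit of the assay.
Compound 2 `CC(=O)Nc1sc2c(c1C(=O)OC(C)(C)C)CCCCC2` — compound 2 gives > 50000 nM, again a limit.
Compound 3 `CC(C)(C)OC(=O)c1c(N)sc2c1CCCCC2` — compound 3 gives > 50000 nM, also a limit.

All three values therefore sit at the same limit, as stated by the limit of > 50000 nM in this assay, at which 3 of the 3 values shown sit. The only step between measured compounds that differ in one place, a step that the two limits leave unreadable from compound 2 to compound 3, cannot be read as a number, so the shared core has so far shown no measurable toxicity in this assay, and compound 1 stands at that limit together with the other two.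

Compound 4 `COc1cccc(NC(=O)c2c(NC(=O)C(F)(F)F)sc3c2CCCCC3)c1` differs from compound 1 by 3-methoxyphenyl in place of 4-chlorophenyl on an amide-type nitrogen. Among the compounds with values here, no measured step touches the group on the amide-type nitrogen, so nothing among the three compounds speaks for a change beyond the scatter, and the three limits speak against a move into the readable range. Compound 4 is therefore expected to give 60000 nM, within a range from 25000 nM to 200000 nM. For compound 4 this estimate means a step that the limit leaves unreadable from compound 1 to compound 4, a step expected to remain within the scatter, most likely again reported only as a limit.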

Compound 4, half-maximal cytotoxic concentration: 37600 nM
The estimate for compound 4 lay 1.6-fold (0.20 log units) above the measured number; the measured number falls inside the stated range.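

In this assay compound 4 gives 37600 nM, the first readable number among the compounds shown. The group on the amide-type nitrogen is therefore a place where the read-out can come off the limit shared by compound 1, compound 2 and compound 3: the limit of > 50000 nM in this assay, at which 3 of the 4 values shown sit. Putting 3-methoxyphenyl in place of 4-chlorophenyl there gives an at least 1.3-fold lower number from compound 1 to compound 4 (0.12 log units; that floor lies within the scatter), so this change is not shown to reach beyond the scatter. Within the data shown here, its true size stays unread, as only one end of the step is a number, and the result shows no more than that toxicity in this test has become readable for this compound at a high concentration.

The compounds shown leave open whether the readable number goes with the methoxy group that enters or with the chlorine that leaves, a question that a plain phenyl on the amide-type nitrogen would help to settle. As far as these compounds go, how a carboxylic acid or an amine on that phenyl ring would read in this assay also stays open.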